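Swapping a methyl for bromo on a cinnamoyl pyranone

The source may hold more compounds than are shown below. What is called first, only, known or untested is meant among the compounds shown, and "the series" means these compounds.

Measured compounds:
compound 1 `Cc1cccc(/C=C/C(=O)c2c(O)cc(C)oc2=O)c1`, 100000 nM
compound 2 `COc1cc(OC)c(OC)cc1/C=C/C(=O)c1c(O)cc(C)oc1=O`, 100000 nM
compound 3 `Cc1cc(O)c(C(=O)/C=C/c2ccccc2Cl)c(=O)o1`, a limit

Compound 1 is a cinnamoyl pyranone. In an ADME assay on HEK293 cells (Homo sapiens) for cytotoxicity, read by MTT assay (on this read-out higher numbers stand for weaker inhibition and lower numbers for stronger inhibition), compound 1 gives 100000 nM, and compound 2 gives 100000 nM, the same figure within the scatter, so neither ranks above the other. Compound 3 gives only a limit of the assay, > 100000 nM, as the evidence notes: the limit of > 100000 nM in this assay, at which 1 of the 3 values shown sits. Compound 4 `Cc1cc(O)c(C(=O)/C=C/c2cccc(Br)c2)c(=O)o1` carries bromo in place of methyl on an aromatic carbon. Among the measured compounds shown here, no measured pair shows how such a swap moves this assay, so no step beyond the scatter is expected in either direction, and the estimated step from compound 1 to compound 4 is no change at the digits printed from compound 1 to compound 4 (within the scatter). Compound 4 is thus expected to give about 100000 nM, within 50000 nM to 200000 nM, and may again register only as a limit.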

Compound 4, half-maximal inhibitory concentration: 100000 nM
For compound 4 middle estimate and measured number coincide at the digits printed, within the range that was stated.
By their numbers in this assay, from the lowest: compounds 1, 2 and 4 (each within the scatter of the next).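

Among the compounds shown here, this pair gives the first direct reading of the swap: in this assay, bromo in place of methyl on an aromatic carbon, meta to a large group, gives no change at the digits printed from compound 1 to compound 4 (within the scatter). At this place, then, the change leaves cytotoxicity in these cells unmoved at the digits printed. The reading may not be sensitive to weaker effects, since the shared figure lies at the edge of what the assay reports: the limit of > 100000 nM in this assay, at which 1 of the 4 values shown sits.

As far as these compounds go, whether an amine or a carboxylic acid at this place would bring the number down remains open.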